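The compounds below may be only part of what the source reports. "The series", "measured", "known", "first", "only" and "open" are said of these compounds alone.

Compound 1 `CC(C)c1onc(-c2c(Cl)cccc2Cl)c1COc1ccc(N(C)Cc2ccc(CCC(=O)O)cc2)c(C(F)(F)F)n1` gives 17 nM in an assay on isolated protein for agonist activity at Bile acid receptor (Homo sapiens), read by FRET; on this read-out higher numbers stand for an effect only at larger amounts of compound and lower numbers for an effect already at smaller amounts.
Compound 2 `CC(C)c1onc(-c2c(Cl)cccc2Cl)c1COc1ccc(N(C)Cc2cccc(C(=O)O)c2)c(C(F)(F)F)n1` gives 12 nM in this assay.
Compound 3 `CN(Cc1cccc(C(=O)O)c1)c1ccc(OCc2c(-c3c(Cl)cccc3Cl)noc2C2CC2)nc1C(F)(F)F` gives 3 nM in this assay.

Compound 3 stands at the lowest of the three numbers in this assay: the step of a 4.0-fold lower number from compound 2 to compound 3 (0.60 log units; beyond the scatter) lies beyond the scatter, and compound 1 sits further away still. Compound 4 `O=C(O)c1ccccc1OCc1ccc(OCc2c(-c3c(Cl)cccc3Cl)noc2C2CC2)nc1C(F)(F)F` differs from compound 3 in one place: (2-carboxyphenoxy)methyl in place of (3-carboxybenzyl)(methyl)amino on an aromatic carbon. This change exchanges both the link to the shared core and the ring that carries the carboxylic acid. Among the compounds with values here, no measured step covers such an exchange. The nearest guide is a 1.4-fold lower number from compound 1 to compound 2 (0.15 log units; within the scatter), where a different acid-bearing ring on the same kind of arm left the number within the scatter, so the acid seems to tolerate some rearrangement. The step of a 4.0-fold lower number from compound 2 to compound 3 (0.60 log units; beyond the scatter) concerns another part of the molecule and says nothing here. From the compounds shown here alone, replacing a nitrogen-linked arm with an oxygen-linked one on that aromatic carbon is untested, so a modest loss is expected rather than none, and the expected step is a 4.0-fold higher number from compound 3 to compound 4 (0.60 log units; beyond the scatter). Compound 4 is therefore estimated at 12 nM in this assay, with a range from 2.5 nM to 60 nM.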

Compound 4, half-maximal effective concentration: 434 nM
Beside the measured number, compound 4's estimate is 36-fold (1.56 log units) below it; measured number outside the range, above it.
By their numbers in this assay, from the lowest: compound 3; then compounds 2 and 1 (each within the scatter of the next); then compound 4.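

Exchanging (3-carboxybenzyl)(methyl)amino for (2-carboxyphenoxy)methyl on this aromatic carbon, ortho to a trifluoromethyl group, gives a 140-fold higher number from compound 3 to compound 4 (2.16 log units; beyond the scatter) in this assay and marks this arm as far less forgiving than the earlier change of acid-bearing ring, a 1.4-fold lower number from compound 1 to compound 2 (0.15 log units; within the scatter) on the same nitrogen-linked arm, had suggested. What is counted changes little: both arms carry a carboxylic acid on a six-membered aromatic ring of carbon only, with the same numbers of hydrogen-bond donors and acceptors, so these shared features alone do not keep the number low. Nothing at hand says why the number climbs so steeply.

The change alters the link to the shared core and the place of the carboxylic acid on its ring together, so the compounds shown cannot separate the share of each in the loss. From the compounds shown here alone, whether a (3-carboxyphenoxy)methyl arm, which would keep the new link while placing the acid as in compound 3, would bring the number back down stays open.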